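Trimming one methoxy group from a weak cell-growth inhibitor

The source may hold more compounds than are shown below. What is called first, only, known or untested is meant among the compounds shown, and "the series" means these compounds.

For the measured compounds named here, compound 2 `COc1cc(-c2nc3cc(/C=C4\SC(=O)N(CC(=O)N5CCOCC5)C4=O)ccc3[nH]2)cc(OC)c1OC` stands at the higher of two numbers so far in a functional assay on HeLa cells (Homo sapiens) for inhibition, read by MTT assay, with a stated time of 48 h; on this read-out lower numbers stand for stronger inhibition and higher numbers for weaker inhibition: compound 2 gives 16300 nM, whereas compound 1 `COc1ccc(-c2nc3cc(/C=C4\SC(=O)NC4=O)ccc3[nH]2)cc1OC` gives 7830 nM, a gap beyond the usual scatter. Compound 3 `COc1ccc(-c2nc3cc(/C=C4\SC(=O)N(CC(=O)N5CCOCC5)C4=O)ccc3[nH]2)cc1OC` keeps all of compound 2 except one change: hydrogen in place of methoxy on an aromatic carbon. Going by the values given here, no measured pair isolates this change, because compound 1 and compound 2 differ in two places at once. The step from compound 2 to compound 3 is therefore expected to be small, a 1.4-fold lower number from compound 2 to compound 3 (0.13 log units; within the scatter), most likely within the scatter. Compound 3 is expected to give about 12000 nM in this assay, somewhere between 4000 nM and 35000 nM.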

Compound 3, half-maximal inhibitory concentration: 7510 nM
For compound 3 the middle estimate is 1.6-fold (0.20 log units) above the measured one; measured number inside the range.
By their numbers in this assay, from the lowest: compounds 3 and 1 (each within the scatter of the next); then compound 2.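

In this assay the change from 3,4,5-trimethoxyphenyl to 3,4-dimethoxyphenyl gives a 2.2-fold lower number from compound 2 to compound 3 (0.34 log units; beyond the scatter) as a modest step, so this one methoxy group does register on its own. Adding ((morpholin-4-yl)carbonyl)methyl on the amide-type nitrogen gives a 1.0-fold lower number from compound 1 to compound 3 (0.02 log units; within the scatter) and stays within the scatter, so with 3,4-dimethoxyphenyl in place that group makes no clear difference. Nothing available explains either result. On these data alone, whether fluorine or hydroxyl on this aromatic carbon would read like hydrogen or like methoxy remains open. So does whether a carboxylic acid or an amine on that nitrogen side chain would shift the number.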